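This account rests on a few compounds, and the source may have more. Where it says the series, first, only, none or still open, it means among the compounds named here.

Compounds measured so far:

Compound 1, `Cc1ccc2oc(-c3ccc(NC(=O)CN4CCN(CCCN(C)C)CC4)c(C)c3)nc2c1`: in a functional assay on C6 cells (Rattus norvegicus) for cytotoxicity, read by MTT assay, with a stated time of 24 h (on this read-out higher numbers stand for weaker inhibition and lower numbers for stronger inhibition), compound 1 gives 7320 nM.
Compound 2, `Cc1ccc2oc(-c3ccc(NC(=O)CN4CCN(CCN(C)C)CC4)cc3)nc2c1`: in this assay compound 2 gives 1630 nM.
Compound 3, `Cc1ccc2oc(-c3ccc(NC(=O)CN4CCN(CCN(C)C)CC4)c(C)c3)nc2c1`: in this assay compound 3 gives 16700 nM.

Compound 2 gives the lowest number of the three in this assay, and both of its companions stand beyond the scatter from it: compound 2 gives 1630 nM, whereas compound 1 gives 7320 nM, and the step to compound 3 is a 10-fold higher number from compound 2 to compound 3 (1.01 log units; beyond the scatter).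

Compound 4, `CN(C)CCN1CCN(CC(=O)Nc2ccc(-c3nc4ccccc4o3)cc2)CC1`, is compound 2 with a single alteration: hydrogen in place of methyl on an aromatic carbon. Among the compounds with values here, no measured step alters this position. Within the data shown here, the one methyl step that has been measured, a 10-fold higher number from compound 2 to compound 3 (1.01 log units; beyond the scatter), concerns a methyl at a different place and so gives no direct guide, while a 2.3-fold higher number from compound 1 to compound 3 (0.36 log units; beyond the scatter) concerns the chain and not the rings at all. With nothing on record for the 5-methyl-1,3-benzoxazol-2-yl to 1,3-benzoxazol-2-yl change, the expectation is a small step in this assay, perhaps toward a slightly higher number, and quite possibly within the scatter. Compound 4 is therefore estimated at 2500 nM, within 900 nM to 7000 nM, which means an expected step of a 1.5-fold higher number from compound 2 to compound 4 (0.19 log units; within the scatter).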

Compound 4, half-maximal inhibitory concentration: 7010 nM
Beside the measured number, compound 4's estimate is 2.8-fold (0.45 log units) below it; measured number above the stated range.
By their numbers in this assay, from the lowest: compound 2; then compounds 4 and 1 (each within the scatter of the next); then compound 3.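

In this assay, within the data shown here, the 5-methyl-1,3-benzoxazol-2-yl to 1,3-benzoxazol-2-yl change gives a 4.3-fold higher number from compound 2 to compound 4 (0.63 log units; beyond the scatter), so this methyl on an aromatic carbon of the fused system is not a silent feature of compound 2, and it is the first position in the fused system for which a step can be read. Its direction also differs from that of the only other methyl step: there, adding a methyl at a different place gives a 10-fold higher number from compound 2 to compound 3 (1.01 log units; beyond the scatter), whereas here it is losing a methyl that raises the number, so among these compounds a methyl has no single direction of effect, and the step at the other place remains the larger of the two. Nothing available accounts for the step seen at this position.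

The compounds shown leave open how an ethyl, a methoxy or a chlorine on this same carbon would compare with the methyl and the hydrogen of compounds 2 and 4. They also leave open whether removing this methyl has the same effect when the second methyl of compound 3 is present, or when the longer chain of compound 1 is.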